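The compounds below may be only part of what the source reports. "The series", "measured", "known", "first", "only" and "open" are said of these compounds alone.

Of the compounds shown here, three have been measured in a functional assay on MIA PaCa-2 cells (Homo sapiens) for inhibition, read by MTT assay, with a stated time of 7 days; a lower number here means a stronger inhibitor, a higher number a weaker inhibitor. For the measured compounds named here, compound 1 `O=C([C@@H]1CCCN(S(=O)(=O)c2ccc(S(=O)(=O)C3CCC3)cc2)C1)N1CCC(F)(F)CC1` gives 9 nM, and compound 3 `O=C([C@@H]1CCCN(S(=O)(=O)c2ccc(S(=O)(=O)C3CC3)cc2)C1)N1CCC(F)(F)CC1` gives 26 nM; the step between them, a 2.9-fold higher number from compound 1 to compound 3 (0.46 log units; beyond the scatter), is the only single-change comparison among the measured compounds. Compound 2 `CCN(CC)S(=O)(=O)c1ccc(S(=O)(=O)N2CCC[C@@H](C(=O)NC3COC3)C2)cc1` gives 2340 nM, the highest of the three numbers, far beyond the scatter from compound 3 and further still from compound 1.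

Compound 4 `CCN(CC)S(=O)(=O)c1ccc(S(=O)(=O)N2CCC[C@@H](C(=O)N[C@@H]3CCOC3)C2)cc1` differs from compound 2 in one place: oxolan-3-yl in place of oxetan-3-yl on an amide-type nitrogen, so a four-membered ring with one oxygen is swapped for a five-membered ring with one oxygen on the amide-type nitrogen. Going by the values given here, no measured step touches this position; the one step on record, from compound 1 to compound 3, changes ring size at the sulfonyl sulfur instead and was modest. By analogy, a step of similar size at most is expected in this assay, with no clear direction. Compound 4 is therefore estimated at 1500 nM, within 500 nM to 5000 nM, which would mean a 1.6-fold lower number from compound 2 to compound 4 (0.19 log units; within the scatter).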

Compound 4, half-maximal inhibitory concentration: 750 nM
Compound 4: middle estimate off by 2.0-fold (0.30 log units), on the high side, and the stated range covers the measured number.
By their numbers in this assay, from the lowest: compound 1; then compound 3; then compound 4; then compound 2.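

In this assay, the group on the amide-type nitrogen proves able to shift the number: oxolan-3-yl in place of oxetan-3-yl gives a 3.1-fold lower number from compound 2 to compound 4 (0.49 log units; beyond the scatter). For the compounds shown here, this is a modest change, yet it is the first measured at this position, and it shows that adding one ring atom here is enough to move the result beyond the scatter. The larger ring also carries the lower number in the earlier pair, where moving from cyclobutyl to cyclopropyl on a sulfonyl sulfur gives a 2.9-fold higher number from compound 1 to compound 3 (0.46 log units; beyond the scatter), but nothing on hand explains this shared direction.

As far as these compounds go, whether oxan-4-yl, with a six-membered ring, would lower the number further remains open, as does the effect of cyclopentyl, which has carbon in place of the ring oxygen. Compound 4 has one defined stereocentre, and the mirror-image oxolan-3-yl group is also left open.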